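Compound 4: a hydroxy-bearing acyl group on the core of compound 1

The source may hold more compounds than are shown below. What is called first, only, known or untested is meant among the compounds shown, and "the series" means these compounds.

Measured in a functional assay on NCI-H1975 cells (Homo sapiens) for antiproliferative activity (a higher number here means a weaker inhibitor, a lower number a stronger inhibitor), so far:
- compound 1 `CC(=O)N1CCc2c(C)c3c(n2-c2ccc(C(N)=O)c(c2)N[C@@H](C)[C@H](C)C1)CC(C)(C)CC3=O` gives 15 nM
- compound 2 `Cc1c2c(n3c1CCCN(C(=O)CN)[C@@H](C)[C@H](C)Nc1cc-3ccc1C(N)=O)CC(C)(C)CC2=O` gives 380 nM
- compound 3 `Cc1c2c(n3c1CCCN(C(=O)CO)[C@@H](C)[C@H](C)Nc1cc-3ccc1C(N)=O)CC(C)(C)CC2=O` gives 54 nM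

Compound 1 has the lowest number of the three, and both other values lie beyond the scatter from it. Compound 4 `Cc1c2c(n3c1CCN(C(=O)[C@H](C)O)C[C@@H](C)[C@H](C)Nc1cc-3ccc1C(N)=O)CC(C)(C)CC2=O` is still unmeasured in this assay and differs from compound 1 as follows: 1-hydroxyethyl in place of methyl on a carbonyl carbon. In words, 1-hydroxyethyl stands in place of methyl on a carbonyl carbon.

Among the compounds with values here, one measured step bears on this, and only indirectly. It is a 7.0-fold lower number from compound 2 to compound 3 (0.85 log units; beyond the scatter), with hydroxy in place of amino on a saturated chain carbon bound to a carbonyl carbon. Within the data shown here, no measured pair isolates the change from methyl to 1-hydroxyethyl. Compound 3, which carries a hydroxy group on such a chain, gives 54 nM and so sits above compound 1 without approaching compound 2. A small step toward a higher number is therefore expected, near the edge of the scatter. The expected value for compound 4 is 30 nM, within an estimated range of 10 nM to 90 nM. That estimate means a 2.0-fold higher number from compound 1 to compound 4 (0.30 log units; within the scatter).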

Compound 4, half-maximal inhibitory concentration: 52 nM
Compound 4: middle estimate off by 1.7-fold (0.24 log units), on the low side; low and high end bracket the measured number.
By their numbers in this assay, from the lowest: compound 1; then compounds 4 and 3 (each within the scatter of the next); then compound 2.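

In this assay, replacing methyl with 1-hydroxyethyl on the carbonyl carbon gives a 3.5-fold higher number from compound 1 to compound 4 (0.54 log units; beyond the scatter), a modest step that shows this place accepts the larger group at a measurable loss. The earlier step compared hydroxy with amino on a chain carbon, whereas this one compares a hydroxy-bearing group with plain methyl on the core of compound 1, and the change also brings in a defined stereocentre. Nothing measured here explains the step.

The change adds carbon, hydroxy and a stereocentre at once, so its effect cannot be assigned to any one of them; an ethyl group on the same carbonyl carbon would separate the carbon from the hydroxy. On these data alone, the opposite configuration of 1-hydroxyethyl and a 1-aminoethyl group also remain open at this place.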